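A Chlorophenyl Variant of the Weakest Inhibitor

The compounds below may be only part of what the source reports. "The series", "measured", "known", "first", "only" and "open" are said of these compounds alone.

Of the compounds shown here, three sharing one core have been tested in an assay on Sf9 cells for inhibition of serine/threonine-protein kinase 4 (Homo sapiens), read by luminescence and ADP-Glo, with a stated time of 1 h, in the presence of a further agent that is not named here; on this read-out higher numbers stand for weaker inhibition and lower numbers for stronger inhibition. Compound 1 `CCCC1C(=O)N(C)c2cnc(Nc3ccc(S(N)(=O)=O)cc3)nc2N1C` gives 206 nM and compound 2 `CN1C(=O)C(CC2CC2)N(C)c2nc(Nc3ccc(S(N)(=O)=O)cc3)ncc21` gives 211 nM; the step of a 1.0-fold higher number from compound 1 to compound 2 (0.01 log units; within the scatter) lies within the scatter. Compound 3 `CN1C(=O)C(c2ccc(F)cc2)N(C)c2nc(Nc3ccc(S(N)(=O)=O)cc3)ncc21` gives 1770 nM, the highest number of the three: the steps of an 8.6-fold higher number from compound 1 to compound 3 (0.93 log units; beyond the scatter) and an 8.4-fold higher number from compound 2 to compound 3 (0.92 log units; beyond the scatter) both lie beyond the scatter, so compound 3 is the weakest inhibitor among them.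

Compound 4 `CN1C(=O)C(c2ccccc2Cl)N(C)c2nc(Nc3ccc(S(N)(=O)=O)cc3)ncc21` differs from compound 3 in one place: 2-chlorophenyl in place of 4-fluorophenyl on a saturated ring carbon. For the measured compounds named here, none of the measured steps swaps one aromatic ring for another; the two steps leading to compound 3 only show that an aromatic ring on that saturated ring carbon gives a higher number than a chain does. The data therefore give no ground to expect a step beyond the scatter in this assay from compound 3 to compound 4, in either direction. Compound 4 is expected to give about 1500 nM, within 500 nM to 5000 nM, meaning an estimated step of a 1.2-fold lower number from compound 3 to compound 4 (0.07 log units; within the scatter).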

Compound 4, half-maximal inhibitory concentration: 129 nM
Beside the measured number, compound 4's estimate is 12-fold (1.07 log units) above it, and the stated range ends above it.
By their numbers in this assay, from the lowest: compounds 4, 1 and 2 (each within the scatter of the next); then compound 3.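

In this assay, the swap from 4-fluorophenyl to 2-chlorophenyl on the saturated ring carbon gives a 14-fold lower number from compound 3 to compound 4 (1.14 log units; beyond the scatter) even though the two groups have the same count of heavy atoms and neither carries a hydrogen-bond donor or acceptor. An aromatic ring at this position therefore does not by itself go with a higher number: the chains and the 2-chlorophenyl group cannot be told apart, with a 1.6-fold lower number from compound 1 to compound 4 (0.20 log units; within the scatter) and a 1.6-fold lower number from compound 2 to compound 4 (0.21 log units; within the scatter) in this assay. Nothing measured here gives a reason for the large gap between the two aromatic groups. The step changes both the halogen and its place on the ring at once, and the compounds shown do not separate the two; 2-fluorophenyl or 4-chlorophenyl on the same carbon would do so. On these data alone, how a phenyl ring with no halogen compares also remains open.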